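Adding a third methoxy group: a step into untested ground

A few compounds are considered here, and "the series" means these few. Any claim that something is new, unique, unknown or untested is made for them only; others in the source may bear on it.

In a functional assay on OVCAR-8 cells (Homo sapiens) for inhibition, read by sulforhodamine B assay, with a stated time of 48 h (on this read-out lower numbers stand for stronger inhibition of growth and higher numbers for weaker inhibition of growth), compound 1 `Nc1cc(N)c2nc(-c3ccccc3)c(NCc3ccc(Cl)c(Cl)c3)nc2c1` gives 13500 nM, and compound 2 `COc1ccc(CNc2nc3cc(N)cc(N)c3nc2-c2ccccc2)cc1OC` gives 33900 nM. Within the data shown here, compound 2 stands at the higher of the two numbers, that is, it inhibits growth more weakly; the only measured step, a 2.5-fold higher number from compound 1 to compound 2 (0.40 log units; beyond the scatter), swapped the 3,4-dichlorophenyl for a 3,4-dimethoxyphenyl and is beyond the scatter.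

Compound 3 `COc1cc(CNc2nc3cc(N)cc(N)c3nc2-c2ccccc2)cc(OC)c1OC` keeps everything of compound 2 and differs only by methoxy in place of hydrogen on an aromatic carbon, so that the ring now carries three methoxy groups. Among the measured compounds shown here, no measured step shows what a single added methoxy on this ring does; the step from compound 1 to compound 2 changed two groups at once and points to a different kind of change. It therefore gives only weak guidance. With nothing in the data speaking for a move beyond the scatter, compound 3 is expected to stay close to compound 2, with the estimated step from compound 2 to compound 3 in this assay being a 1.1-fold higher number from compound 2 to compound 3 (0.03 log units; within the scatter). The estimated value for compound 3 is 36000 nM, within a range of 15000 nM to 85000 nM.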

Compound 3, concentration for total growth inhibition: 14800 nM
The estimate for compound 3 lay 2.4-fold (0.39 log units) above the measured number; the whole stated range lies above it.
By their numbers in this assay, from the lowest: compounds 1 and 3 (each within the scatter of the next); then compound 2.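

In this assay, methoxy in place of hydrogen on an aromatic carbon, ortho to a methoxy group and meta to a large group, gives a 2.3-fold lower number from compound 2 to compound 3 (0.36 log units; beyond the scatter) and so strengthens growth inhibition beyond the usual scatter. This shows that the position is not indifferent to substitution, and that a single added group on this ring can shift the read-out by itself. The earlier step, a 2.5-fold higher number from compound 1 to compound 2 (0.40 log units; beyond the scatter), replaced two chlorines with two methoxy groups and went towards weaker inhibition, so the step from compound 2 to compound 3 shows that more methoxy on this ring does not simply mean weaker inhibition. Nothing available explains why the added methoxy has this effect.

On these data alone, it remains open whether other groups at this position, such as a hydroxyl, an ethoxy or an amine, would move the number in the same direction or whether the shift is particular to methoxy. As far as these compounds go, it is also open whether the third methoxy would have the same effect without the other two, or whether a methoxy added to the dichlorinated ring of compound 1 would shift the number as it does here.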